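A few compounds are considered here, and "the series" means these few. Any claim that something is new, unique, unknown or untested is made for them only; others in the source may bear on it.

Compound 1 `COc1ccc(C2=NN(C(=O)C(C)O[N+](=O)[O-])C(c3ccco3)C2)cc1OC` gives 42%; compound 2 `COc1ccc(C2CC(c3ccc(OC)c(OC)c3)=NN2C(=O)C(C)O[N+](=O)[O-])c(OC)c1` gives 56%.

Compound 2 holds the higher of the two numbers in a functional assay on the whole organism (strain albino) for inhibition, with Rattus norvegicus as the target, read by paw edema, with stated times of 30 min and 3 h, at a dose of 100 mg/kg by the oral route; on this read-out lower numbers stand for less inhibition and higher numbers for more inhibition at the one dose given (going by the name of the read-out); compound 1 sits below it by a number 14 percentage points higher from compound 1 to compound 2 (beyond the scatter). Compound 3 `COc1ccc(C2=NN(C(=O)C(C)O[N+](=O)[O-])C(c3c(Cl)cccc3Cl)C2)cc1OC` differs from compound 2 by 2,6-dichlorophenyl in place of 2,4-dimethoxyphenyl on a saturated ring carbon. Among the compounds with values here, the only measured step at that saturated ring carbon, a number 14 percentage points higher from compound 1 to compound 2 (beyond the scatter), exchanged furan-2-yl for 2,4-dimethoxyphenyl, a different exchange from the one made here, so it tells where the change sits but not which way it runs. Within the data shown here, with no closer precedent, compound 3 is expected to land near the two measured values, and the step of a number 6 percentage points lower from compound 2 to compound 3 (within the scatter) is expected to stay within the scatter. The estimate for compound 3 in this assay is 50%, ranging from 35% to 65%.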

Compound 3, a percentage reported as inhibition, in the whole organism at one dose (the size of the read-out at that dose, not a potency): 55%
Estimate against measurement, compound 3: 5 percentage points below; the range from low to high includes it.
By their numbers in this assay, from the lowest: compound 1; then compounds 3 and 2 (each within the scatter of the next).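

In this assay, the 2,6-dichlorophenyl and 2,4-dimethoxyphenyl groups on this saturated ring carbon cannot be told apart, with a number 1 percentage points lower from compound 2 to compound 3 (within the scatter). The comparison with furan-2-yl now has a second reading, a number 13 percentage points higher from compound 1 to compound 3 (beyond the scatter), so two differently substituted phenyl groups each stand clear of compound 1. Nothing given here accounts for this result.

The compounds shown leave open whether unsubstituted phenyl would stay level with compound 2 and compound 3. They also leave open how an amine or a carboxylic acid on this carbon would read.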